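The compounds below may be only part of what the source reports. "The series", "measured", "known", "first", "only" and "open" are said of these compounds alone.

In an assay on CHO cells for antagonist activity at transient receptor potential cation channel subfamily V member 1 (Homo sapiens), read by FLIPR (a higher number here means a weaker inhibitor, a lower number a stronger inhibitor), compound 1 `CC1CCN(c2cc(C(F)(F)F)ccc2CNC(=O)C(C)c2ccc(NS(C)(=O)=O)c(F)c2)CC1` gives 0.9 nM. Among the three compounds measured so far this is the highest number. Compound 3 `Cc1ccc(N2CCN(c3cc(C(F)(F)F)ccc3CNC(=O)C(C)c3ccc(NS(C)(=O)=O)c(F)c3)CC2)cc1` gives 0.7 nM, and these two numbers lie within the usual scatter of each other. Among the compounds with values here, compound 2 `CC(C(=O)NCc1ccc(C(F)(F)F)cc1N1CCC(Cc2ccc(F)cc2)CC1)c1ccc(NS(C)(=O)=O)c(F)c1` gives 0.4 nM; the change a 2.3-fold lower number from compound 1 to compound 2 (0.35 log units; beyond the scatter) is the single measured step available, modest but beyond the scatter.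

Compound 4 `CC(C(=O)NCc1ccc(C(F)(F)F)cc1OCc1ccc(F)cc1)c1ccc(NS(C)(=O)=O)c(F)c1` has not been measured. It differs from compound 1 in one place: (4-fluorobenzyl)oxy in place of 4-methylpiperidin-1-yl on an aromatic carbon. The measured step also brings in a 4-fluorophenyl group and gave a modestly lower number, but there the 4-methylpiperidin-1-yl group stayed in place, whereas in compound 4 that group leaves and the (4-fluorobenzyl)oxy group enters on an aromatic carbon of the shared core. Within the data shown here, no measured pair shows what removing the 4-methylpiperidin-1-yl group does. The step expected from this change is therefore small, and its estimate is a 1.7-fold higher number from compound 1 to compound 4 (0.22 log units; within the scatter). Compound 4 is expected to give about 1.5 nM, with a likely range from 0.5 nM to 5 nM.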

Compound 4, inhibition constant: 0.5 nM
Compound 4: middle estimate off by 3.0-fold (0.48 log units), on the high side, and the stated range covers the measured number.
By their numbers in this assay, from the lowest: compounds 2, 4, 3 and 1 (each within the scatter of the next, the first and the last beyond it).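

In this assay, replacing 4-methylpiperidin-1-yl with (4-fluorobenzyl)oxy on this aromatic carbon gives a 1.8-fold lower number from compound 1 to compound 4 (0.26 log units; within the scatter), a step within the scatter. The three earlier compounds all carry a group attached through nitrogen at this place, so they could not show whether that nitrogen link was needed. Compound 4 shows that a group attached through oxygen, with a six-membered aromatic ring of carbon only in place of the non-aromatic ring, keeps the number in the same low range. Nothing available explains why these two different groups give such similar numbers.

The compounds shown leave open whether a much smaller group on this carbon, such as methoxy, would keep this level of inhibition. They also leave open what a plain benzyloxy group, without the fluorine, would give.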